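Sulfonate amides and ureas: tail variation, antiproliferative activity

This account rests on a few compounds, and the source may have more. Where it says the series, first, only, none or still open, it means among the compounds named here.

Compound 1 `CCC(=O)Nc1ccc(S(=O)(=O)Oc2ccccc2C(C)C)cc1` gives 7400 nM in a functional assay on HT-29 cells (Homo sapiens) for antiproliferative activity, read by sulforhodamine B assay, with a stated time of 48 h; a higher number here means a weaker inhibitor, a lower number a stronger inhibitor.
Compound 2 `CCCCCC(=O)Nc1ccc(S(=O)(=O)Oc2ccccc2C(C)C)cc1` gives 6400 nM in this assay.
Compound 3 `CC(C)c1ccccc1OS(=O)(=O)c1ccc(NC(=O)NCCCCl)cc1` gives 6900 nM in this assay.

Compound 3 stands second highest of the three numbers; the nearest is compound 1 and the furthest compound 2, and the gap to each lies within the scatter. The shared core is carried through unchanged, the three compounds differing only at the carbonyl end. The steps there are all flat: a 1.2-fold lower number from compound 1 to compound 2 (0.06 log units; within the scatter); a 1.1-fold lower number from compound 1 to compound 3 (0.03 log units; within the scatter); a 1.1-fold higher number from compound 2 to compound 3 (0.03 log units; within the scatter).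

Compound 4 `CC(C)c1ccccc1OS(=O)(=O)c1ccc(NC(=O)NCC2CCCC2)cc1` differs from compound 3 in one place: cyclopentyl in place of 2-chloroethyl on a saturated chain carbon bound to an amide-type nitrogen. Within the data shown here, no measured step puts a carbocycle at this position, so the only guide is that chain length and amide versus urea at this end moved nothing beyond the scatter. For compound 4 the expected step is therefore a 1.1-fold lower number from compound 3 to compound 4 (0.03 log units; within the scatter), in no direction beyond the scatter. Compound 4 is estimated at 6500 nM, with a range from 3000 nM to 14000 nM.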

Compound 4, half-maximal inhibitory concentration: 6800 nM
Estimate against measurement, compound 4: 1.0-fold (0.02 log units) below; low and high end bracket the measured number.
By their numbers in this assay, from the lowest: compounds 2, 4, 3 and 1 (each within the scatter of the next).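

In this assay cyclopentyl in place of 2-chloroethyl on a saturated chain carbon bound to an amide-type nitrogen gives a 1.0-fold lower number from compound 3 to compound 4 (0.01 log units; within the scatter) and so adds the first ring at this end and removes the chlorine without a change beyond the scatter. Against the amides, the (cyclopentylmethyl)amino tail gives a 1.1-fold higher number from compound 2 to compound 4 (0.03 log units; within the scatter) and a 1.1-fold lower number from compound 1 to compound 4 (0.04 log units; within the scatter), so the flat picture now takes in a carbocycle as well as open chains. No evidence in hand bears on the reason for this flatness.

Going by these compounds, all four compounds lie within the scatter of one another, so it remains open whether a tail carrying an amine, a carboxylic acid or a phenyl ring would move the number beyond it. The shared core is constant throughout, and these compounds say nothing about changes there.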